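Bromo in place of fluoro on compound 3

The source may report more compounds than this note shows. Statements on the series, on what has been measured and on what is new or still open speak of the compounds shown alone.

compound 1 `COc1cc(CCc2ccccn2)cc(OC)c1O`: 660 nM
compound 2 `COc1cc(CCc2ccccc2)cc(OC)c1O`: 1040 nM
compound 3 `COc1cc(CCc2ccc(F)cc2)cc(OC)c1O`: 10700 nM

In a functional assay on MKN-45 cells (Homo sapiens) for antiproliferative activity, read by MTT assay, with a stated time of 72 h (a higher number here means a weaker inhibitor, a lower number a stronger inhibitor), compound 3 stands highest of the three, at 10700 nM. Compound 4 `COc1cc(CCc2ccc(Br)cc2)cc(OC)c1O` carries bromo in place of fluoro on an aromatic carbon. Within the data shown here, no measured step makes this exchange. The closest evidence is a 10-fold higher number from compound 2 to compound 3 (1.01 log units; beyond the scatter), fluoro in place of hydrogen at the same place, a large step. The other, a 1.6-fold higher number from compound 1 to compound 2 (0.20 log units; within the scatter), concerns a different place and bears little on it. How bromo compares with fluoro remains unmeasured, so only a partial, uncertain return is expected. The expected change is a 2.1-fold lower number from compound 3 to compound 4 (0.33 log units; beyond the scatter), towards a lower number. Compound 4 is estimated at 5000 nM, with an expected range of 1200 nM to 20000 nM.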

Compound 4, half-maximal inhibitory concentration: 1490 nM
Compound 4: middle estimate off by 3.4-fold (0.53 log units), on the high side; the measured number falls inside the stated range.
By their numbers in this assay, from the lowest: compounds 1, 2 and 4 (each within the scatter of the next, the first and the last beyond it); then compound 3.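

In this assay the identity of the halogen at this place matters: a 7.2-fold lower number from compound 3 to compound 4 (0.86 log units; beyond the scatter), so the large loss seen with fluoro does not carry over to bromo. Set against hydrogen, a 1.4-fold higher number from compound 2 to compound 4 (0.16 log units; within the scatter), which leaves bromo within the scatter of the unsubstituted ring. Nothing available explains why the two halogens differ. Open, from the compounds shown here alone, is where chloro, methoxy or an amine at this same place would fall, and whether fluoro is an isolated case. Also open, going by these compounds, is whether bromo would behave the same on the pyridin-2-yl ring of compound 1.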